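Dropping One Hydroxy Group From a Catechol Compound

The source may report more compounds than this note shows. Statements on the series, on what has been measured and on what is new or still open speak of the compounds shown alone.

Compounds measured in an assay on isolated protein for inhibition of Alpha glucosidase (Homo sapiens), with stated times of 5 min and 15 min, tested at 50 uM; on this read-out lower numbers stand for less inhibition and higher numbers for more inhibition at the one concentration tested (going by the name of the read-out):
Compound 1 `Cc1ccc(/C=C2\CCC/C(=C\c3ccccc3)C2=O)cc1` gives 34.1%.
Compound 2 `O=C(C1=C(O)/C(=C/c2ccc(O)c(O)c2)CCC1)c1ccccc1` gives 55.9%.
Compound 3 `O=C1/C(=C/c2ccccc2)CCC/C1=C\c1ccc(F)c(F)c1` gives 37.8%.

Of these three numbers, compound 2 stands highest. Compound 3 comes nearest, yet its number sits lower by a gap that goes beyond the usual scatter, and compound 1 lies lower still, also beyond the scatter. Compound 2 is the only one of the three that carries hydroxy groups on its aromatic ring; compounds 1 and 3 carry none or fluorine instead.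

Compound 4 `O=C(C1=C(O)/C(=C/c2cccc(O)c2)CCC1)c1ccccc1` has not yet been measured. It differs from compound 2 in one place: hydrogen in place of hydroxy on an aromatic carbon. One of the two hydroxy groups is thus gone, so that compound 4 sits between compound 2 and the hydroxy-free compounds 1 and 3 in how much it carries on that ring.

Going by the values given here, no measured pair shows this exact change, so the expected step rests on the spread of the three numbers alone. In this assay a downward step from compound 2 to compound 4 is expected, of a size near the edge of the scatter, a number 10.9 percentage points lower from compound 2 to compound 4 (beyond the scatter). For compound 4 a value of about 45% is expected, within a range from 30% to 60%.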

Compound 4, a percentage reported as inhibition, at one concentration (the size of the read-out at that concentration, not a potency): 43.2%
Compound 4: middle estimate off by 1.8 percentage points, on the high side, within the range that was stated.
By their numbers in this assay, from the lowest: compounds 1, 3 and 4 (each within the scatter of the next); then compound 2.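

In this assay, going by these compounds alone, the change from 3,4-dihydroxyphenyl to 3-hydroxyphenyl gives a number 12.7 percentage points lower from compound 2 to compound 4 (beyond the scatter) and isolates a single hydroxy group, one ortho to a hydroxy group and para to a large group, whereas the earlier compounds differed from one another in more than one place and could not single it out. This hydroxy group therefore contributes to the inhibition seen at the one tested concentration, but its loss does not abolish that inhibition, since compound 4 still gives 43.2% in this assay as a read-out at that concentration rather than a measure of potency. No measurement shown here explains why the number falls with this change.

The compounds shown leave open whether a methoxy group or an amine at this position would keep the number near that of compound 2, or whether only a hydroxy group can do so. They also leave open what removing the remaining hydroxy group from compound 4 would do, and how the 4-hydroxyphenyl counterpart would compare.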